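One more methoxy on compound 3

The source may hold more compounds than are shown below. What is called first, only, known or untested is meant among the compounds shown, and "the series" means these compounds.

Measured in a functional assay on HeLa cells (Homo sapiens) for antiproliferative activity, read by cell counting, with a stated time of 2 days; a higher number here means a weaker inhibitor, a lower number a stronger inhibitor:
compound 1 `COc1ccc(C(=O)c2sc(Nc3ccccc3)nc2N)cc1OC` gives 6000 nM
compound 2 `COc1cc(C(=O)c2sc(Nc3ccc(F)cc3)nc2N)cc(OC)c1OC` gives 440 nM
compound 3 `COc1ccc(Nc2nc(N)c(C(=O)c3ccc(OC)c(OC)c3)s2)cc1` gives 52 nM

Compound 3 has the lowest number of the three in this assay, and its gaps to compound 1 and to compound 2 both lie beyond the scatter. The next compound, compound 4 `COc1ccc(Nc2nc(N)c(C(=O)c3cc(OC)c(OC)c(OC)c3)s2)cc1`, differs from compound 3 at one place: methoxy in place of hydrogen on an aromatic carbon. This is a methoxy in place of hydrogen on an aromatic carbon.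

For the measured compounds named here, only one measured step involves the same kind of change. It is a 120-fold lower number from compound 1 to compound 3 (2.06 log units; beyond the scatter), a large step beyond the scatter, but there the methoxy entered at another place in the molecule, so it bears on compound 4 only indirectly. Compound 2 already carries a methoxy at the place in question and gives 440 nM, a lower number than compound 1 at 6000 nM, although those two differ at more than this one place. Both observations point towards a lower number, with no direct measurement of this change. The expected change is a 6.5-fold lower number from compound 3 to compound 4 (0.81 log units; beyond the scatter), a moderate step beyond the scatter. For compound 4 the estimated value is 8 nM, with an expected range from 1.5 nM to 45 nM.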

Compound 4, half-maximal inhibitory concentration: 560 nM
The estimate for compound 4 lay 70-fold (1.85 log units) below the measured number; the measured number lies above the stated range.
By their numbers in this assay, from the lowest: compound 3; then compounds 2 and 4 (each within the scatter of the next); then compound 1.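

In this assay, a methoxy on an aromatic carbon, ortho to a methoxy group and meta to a large group, gives an 11-fold higher number from compound 3 to compound 4 (1.03 log units; beyond the scatter), whereas the same kind of change at another place gave a 120-fold lower number from compound 1 to compound 3 (2.06 log units; beyond the scatter). Among these compounds, then, the direction of this change depends on where the methoxy enters, and this position is the first to show a rise in the number. With the added methoxy in place, exchanging the fluoro at the other place for a methoxy gives a 1.3-fold higher number from compound 2 to compound 4 (0.10 log units; within the scatter), so that exchange does not separate these two compounds in the way that the large step from hydrogen to methoxy separated the earlier pair, and nothing shown explains the rise at the new position.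

The compounds shown leave open whether the higher number follows from any group at this position or from the methoxy alone, since a hydroxy, an ethoxy or an amine there could respond differently. They also leave open whether the same rise would appear with a hydrogen or a fluoro at the other place.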